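Fluoro Added to Compound 2: A Single-Point Expectation

This account rests on a few compounds, and the source may have more. Where it says the series, first, only, none or still open, it means among the compounds named here.

Of the compounds shown here, two have so far been measured in a functional assay on MV4-11 cells (Homo sapiens) for antiproliferative activity, read by CellTiter-Glo, with a stated time of 72 h; on this read-out lower numbers stand for stronger inhibition and higher numbers for weaker inhibition. Compound 1 `CO[C@@H]1[C@H](N(C)c2ncc(-c3c[nH]c4ccc(F)cc34)s2)C[C@H]2O[C@]1(C)n1c3ccccc3c3c4c(c5c6ccccc6n2c5c31)C(=O)NC4` gives 510 nM in this assay. Compound 2 `CO[C@@H]1[C@H](N(C)c2ncc(-c3c[nH]c4ccccc34)s2)C[C@H]2O[C@]1(C)n1c3ccccc3c3c4c(c5c6cc(Cl)ccc6n2c5c31)C(=O)NC4` gives 560 nM in this assay, which is the higher of the two numbers recorded, though its gap to compound 1 lies within the scatter, so the two values cannot be told apart. Among the measured compounds shown here, compound 1 and compound 2 differ in more than one place, so no single step connects them. Compound 3 `CO[C@@H]1[C@H](N(C)c2ncc(-c3c[nH]c4ccc(F)cc34)s2)C[C@H]2O[C@]1(C)n1c3ccccc3c3c4c(c5c6cc(Cl)ccc6n2c5c31)C(=O)NC4` differs from compound 2 by fluoro in place of hydrogen on an aromatic carbon. For the measured compounds named here, no step between measured compounds isolates this change, so the expectation for it rests only on the two numbers in hand. The step from compound 2 to compound 3 is expected to be small, a 1.1-fold lower number from compound 2 to compound 3 (0.05 log units; within the scatter), and not beyond the scatter in either direction. For compound 3 the estimate in this assay is 500 nM, with a range from 200 nM to 1300 nM.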

Compound 3, half-maximal inhibitory concentration: 320 nM
Estimate against measurement, compound 3: 1.6-fold (0.19 log units) above; low and high end bracket the measured number.
By their numbers in this assay, from the lowest: compounds 3, 1 and 2 (each within the scatter of the next).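

In this assay, fluoro in place of hydrogen on this aromatic carbon, the change from 1H-indol-3-yl to 5-fluoro-1H-indol-3-yl, now has a step of its own, a 1.8-fold lower number from compound 2 to compound 3 (0.24 log units; within the scatter), read with the chloro present on both compounds. The step that brings in the chloro, read with the fluoro present on both, gives a 1.6-fold lower number from compound 1 to compound 3 (0.20 log units; within the scatter), so neither single change carries the number beyond the scatter, something the two earlier compounds, which differ in more than one place, could not show. Nothing on hand gives a reason for these numbers. The compounds shown leave open whether another group at this position, such as methoxy, a nitrile or an amine, would move the number beyond the scatter. They also leave open whether fluoro gives a similar step on the core without the chloro.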